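A few compounds are considered here, and "the series" means these few. Any claim that something is new, unique, unknown or untested is made for them only; others in the source may bear on it.

Measured compounds:
- Compound 1, `COc1ccc(/C(C)=C/CN2CCC(Cc3ccccc3)CC2)cc1`, gives 4.14 nM.
- Compound 2, `COc1cccc(/C(C)=C/CN2CCC(Cc3ccccc3)CC2)c1`, gives 7.7 nM.
- Compound 3, `C/C(=C\CN(C)Cc1ccccc1)c1ccc2ccccc2c1`, gives 7.88 nM.

Within the data shown here, in an assay on cell membranes for displacement of a labelled ligand from Sigma non-opioid intracellular receptor 1 (Cavia porcellus), read by scintillation counting, with a stated time of 150 min (on this read-out lower numbers stand for stronger inhibition and higher numbers for weaker inhibition), compound 1 has the lowest of the three numbers, but its nearest neighbour compound 2 lies within the scatter, and so does compound 3, so no compound can be called the strongest here. Among the measured compounds shown here, the one step between compounds that differ in a single place, a 1.9-fold higher number from compound 1 to compound 2 (0.27 log units; within the scatter), concerns the methoxy group on the aromatic ring, not the amine end of the molecule.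

Compound 4, `COc1ccc(/C(C)=C/CN2CCCCC2)cc1`, differs from compound 1 at the amine end: hydrogen in place of benzyl on a saturated ring carbon. For the measured compounds named here, no measured step touches this part of the structure, so there is no direct guide. Compound 3 carries a different amine and a different aromatic part at once, and its value against that of compound 1 shows only that a differently built amine end can reach a similar number. Removing a sizeable group is expected to cost some binding, so a higher number is estimated for compound 4, with a 7.2-fold higher number from compound 1 to compound 4 (0.86 log units; beyond the scatter) as the expected step. Compound 4 is estimated at 30 nM, in the range 6 nM to 150 nM.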

Compound 4, inhibition constant: 14 nM
Compound 4: middle estimate off by 2.1-fold (0.33 log units), on the high side, within the range that was stated.
By their numbers in this assay, from the lowest: compounds 1, 2, 3 and 4 (each within the scatter of the next, the first and the last beyond it).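

In this assay, replacing benzyl with hydrogen on the saturated ring carbon gives a 3.4-fold higher number from compound 1 to compound 4 (0.53 log units; beyond the scatter), the first single change shown here that moves the number beyond the scatter. The step is modest: even without the benzyl and its aromatic ring, compound 4 still gives 14 nM, so in this pair that group adds to binding but is not needed for a low number. Nothing available here explains the size of this step.

As far as these compounds go, it remains open whether the aromatic ring of the benzyl matters or whether other groups on that ring carbon, such as a methyl, a phenyl or a cyclohexylmethyl, would give a similar number. The compounds shown also leave open whether this step would keep its size with the methoxy group placed as in compound 2.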